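Replacing the Amide Hydrogen in a Cell-Growth Inhibitor Series

The source may report more compounds than this note shows. Statements on the series, on what has been measured and on what is new or still open speak of the compounds shown alone.

Measured compounds:
Compound 1, `O=C([C@@H]1CCCN(S(=O)(=O)c2ccc(S(=O)(=O)C3COC3)cc2)C1)N1CCC(F)(F)CC1`: 110 nM
Compound 2, `CCN(CC)S(=O)(=O)c1ccc(S(=O)(=O)N2CCC[C@@H](C(=O)N[C@H]3CCOC3)C2)cc1`: 1670 nM

In a functional assay on MIA PaCa-2 cells (Homo sapiens) for inhibition, read by MTT assay, with a stated time of 7 days (on this read-out higher numbers stand for weaker inhibition and lower numbers for stronger inhibition), compound 2 stands at the higher of the two numbers, so it inhibits the cells more weakly than compound 1, and the gap between them lies beyond the usual scatter. Compound 3, `CCN(CC)S(=O)(=O)c1ccc(S(=O)(=O)N2CCC[C@@H](C(=O)N3CC[C@@H](OC)C3)C2)cc1`, differs from compound 2 in one place: 3-methoxypyrrolidin-1-yl in place of (oxolan-3-yl)amino on a carbonyl carbon. For the measured compounds named here, no measured pair shows this change on its own, so its direction is uncertain; a small step, expected to lie within or only just beyond the scatter, is estimated as a 1.7-fold lower number from compound 2 to compound 3 (0.22 log units; within the scatter). Compound 3 is therefore expected to give about 1000 nM, between 300 nM and 3500 nM.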

Compound 3, half-maximal inhibitory concentration: 3910 nM
Compound 3: the middle estimate sits 3.9-fold (0.59 log units) below what was measured; measured number above the stated range.
By their numbers in this assay, from the lowest: compound 1; then compound 2; then compound 3.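

On the carbonyl carbon, replacing (oxolan-3-yl)amino with 3-methoxypyrrolidin-1-yl removes the amide hydrogen, and in this assay this gives a 2.3-fold higher number from compound 2 to compound 3 (0.37 log units; beyond the scatter), a modest weakening. So this position responds to the change, and losing the amide hydrogen brings no gain here. Nothing available explains the shift.

Because the ring and the methoxy group change in the same step, the share of the amide hydrogen itself stays unresolved. Going by these compounds, how a dimethylamino or morpholin-4-yl group would behave on this carbonyl carbon also remains open.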